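Working notes on the aryl variation at the pyranone position

The compounds below may be only part of what the source reports. "The series", "measured", "known", "first", "only" and "open" are said of these compounds alone.

For the measured compounds named here, compound 2 `CCC1=C(O)c2c(oc(-c3ccc(C)cc3C)cc2=O)C(CC)(CC)C1=O` is the only member of this small set with a number in a functional assay on KB cells (Homo sapiens) for antiproliferative activity, read by sulforhodamine B assay, with a stated time of 3 days (a lower number here means that less compound is needed, a higher number that more compound is needed for the effect), where compound 2 gives 41.2 uM. Compound 1 `CCC1=C(O)c2c(oc(-c3ccc(SC)cc3)cc2=O)C(CC)(CC)C1=O` has, in this assay, only a limit: compound 1 reports > 52.1 uM. Going by the values given here, the one measured step, an at least 1.2-fold lower number from compound 1 to compound 2 (0.10 log units; that floor lies within the scatter), rests on that limit and is therefore a floor that cannot be separated from the scatter; its size comes from the cut-off the limit of > 52.1 uM in this assay, at which 1 of the 2 values shown sits, rather than from two numbers.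

Compound 3 `CCC1=C(O)c2c(oc(-c3ccc(OC)c(Cl)c3)cc2=O)C(CC)(CC)C1=O` changes the aryl group again: 3-chloro-4-methoxyphenyl in place of 2,4-dimethylphenyl on an aromatic carbon. Among the compounds with values here, no measured step pairs a 3-chloro-4-methoxyphenyl with any other aryl, so the only guide is that both measured compounds sit in the same weak region of this assay. On that basis the expected step of a 1.1-fold higher number from compound 2 to compound 3 (0.04 log units; within the scatter) is taken as none beyond the scatter, with a real chance that compound 3 also returns only a limit. The estimated value for compound 3 in this assay is 45 uM, with a range from 15 uM to 130 uM.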

Compound 3, concentration for half-maximal effect: 24.9 uM
The estimate for compound 3 lay 1.8-fold (0.26 log units) above the measured number, within the range that was stated.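

In this assay, the change from 2,4-dimethylphenyl to 3-chloro-4-methoxyphenyl gives a 1.7-fold lower number from compound 2 to compound 3 (0.22 log units; within the scatter), so this position can carry a group with chlorine and oxygen and still return a number, but this pair does not separate the two aryl groups. For the compounds shown here, the change from 4-(methylsulfanyl)phenyl to 3-chloro-4-methoxyphenyl gives an at least 2.0-fold lower number from compound 1 to compound 3 (0.32 log units; beyond the scatter), the first step at this position to clear the scatter, so the aryl group here can make at least a modest difference in this assay. Compound 1 has only a limit, so this step is a floor and not a measured size, and it depends on the cut-off: the limit of > 52.1 uM in this assay, at which 1 of the 3 values shown sits.

The compounds shown leave open whether the chlorine or the methoxy group of compound 3 carries the step from compound 1, since the two enter together and neither is seen alone on the aryl ring. Also open, on these data alone, is whether an amine or a carboxylic acid on the aryl ring, or a longer chain in place of the ring, would move the number in this assay beyond the scatter relative to compound 3.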